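The source may hold more compounds than are shown below. What is called first, only, known or untested is meant among the compounds shown, and "the series" means these compounds.

Working notes, compound 4.

Among the measured compounds shown here, compound 2 `Cc1nc(N[C@@H]2C[C@H]3CC[C@@H]2C3)c2cc(-c3ccc(Cl)c(Cl)c3)ccc2n1` gives 419 nM in a functional assay for positive allosteric modulation of GABA-B receptor (Homo sapiens), read by GTPgammaS binding (on this read-out higher numbers stand for an effect only at larger amounts of compound and lower numbers for an effect already at smaller amounts), the highest of the three numbers so far; compound 1 `Cc1nc(N[C@@H]2C[C@H]3CC[C@@H]2C3)c2cc(-c3cccc(Cl)c3)ccc2n1` gives 199 nM and compound 3 `Cc1nc(N[C@@H]2C[C@H]3CC[C@@H]2C3)c2cc(-c3cc(Cl)cc(Cl)c3)ccc2n1` gives 97 nM. Compound 4 `Clc1nc(N[C@@H]2C[C@H]3CC[C@@H]2C3)c2cc(-c3ccc(Cl)c(Cl)c3)ccc2n1` differs from compound 2 by chloro in place of methyl on an aromatic carbon. The measured steps all concern chloro substitution elsewhere in the molecule: a 2.1-fold higher number from compound 1 to compound 2 (0.32 log units; beyond the scatter), a 2.1-fold lower number from compound 1 to compound 3 (0.31 log units; beyond the scatter), a 4.3-fold lower number from compound 2 to compound 3 (0.64 log units; beyond the scatter). None of them touches the position varied here, so they offer no direct guide, and no step beyond the scatter is assumed in either direction. For compound 4 the expected number is 420 nM, within 140 nM to 1300 nM. The expected step is a 1.0-fold higher number from compound 2 to compound 4 (0.00 log units; within the scatter), with the range widened to reflect the absence of any comparable change.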

Compound 4, half-maximal effective concentration: 341 nM
Beside the measured number, compound 4's estimate is 1.2-fold (0.09 log units) above it; the measured number falls inside the stated range.
By their numbers in this assay, from the lowest: compound 3; then compounds 1, 4 and 2 (each within the scatter of the next, the first and the last beyond it).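

In this assay, among the compounds shown here, the first change at this position, on the aromatic carbon between two ring nitrogen atoms, gives a 1.2-fold lower number from compound 2 to compound 4 (0.09 log units; within the scatter). With the 3,4-dichlorophenyl group held constant, methyl and chloro cannot be told apart here, so this position accepts either group without a step beyond the scatter. Nothing available explains this result.

Still open, going by these compounds, is whether an amine, a methoxy group or a longer chain at this position would move the number beyond the scatter. Also open, on these data alone, is whether chloro in place of methyl gives the same result on compound 3, which carries the 3,5-dichlorophenyl group.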